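A few compounds are considered here, and "the series" means these few. Any claim that something is new, unique, unknown or untested is made for them only; others in the source may bear on it.

In an ADME assay on HEK293 cells (Homo sapiens) for cytotoxicity, read by CCK-8 assay, with a stated time of 48 h (a higher number here means a weaker inhibitor, a lower number a stronger inhibitor), compound 2 `COc1ccc(/C=C\c2cc(OC)c(OC)c(OC)c2)cc1OCc1ccc(CN[C@H](C(=O)O)[C@H](C)O)cc1` gives > 50000 nM, which is a limit of the assay and not a number. Compound 1 `COc1ccc(/C=C\c2cc(OC)c(OC)c(OC)c2)cc1OCc1ccc(CNC(C)(C)C(=O)O)cc1` gives > 50000 nM, which is also a limit. Compound 2 therefore has no exact position, and both readings rest on the same ceiling: the limit of > 50000 nM in this assay, at which 2 of the 2 values shown sit.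

The next compound is compound 3 `COc1ccc(/C=C\c2cc(OC)c(OC)c(OC)c2)cc1OCc1ccc(CNCCO)cc1`, which keeps the shared core but has 2-hydroxyethyl in place of 1-carboxy-2-hydroxypropyl on an amine nitrogen.

Among the compounds with values here, the only measured step that bears on this change is a step that the two limits leave unreadable from compound 1 to compound 2. It has no readable size, and it compares two carboxy-bearing groups, so it offers no size to carry over. With compound 2 at > 50000 nM, a limit, any readable number for compound 3 would have to lie lower in this assay, although a second reading at the limit remains quite possible.

The expected change, held loosely, is an at least 1.6-fold lower number from compound 2 to compound 3 (0.22 log units; that floor lies within the scatter). For compound 3 the estimated value is 30000 nM, with an expected range from 5000 nM to 80000 nM.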

Compound 3, half-maximal inhibitory concentration: > 50000 nM
Compound 3 was reported as a limit; the forecaster's own chance of this, stated with the estimate: 50%; middle value at least 1.6-fold (0.22 log units) away from the limit.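

No step can be read among compound 1, compound 2 and compound 3, because each reading in this assay is a limit of the assay and not a number: the limit of > 50000 nM in this assay, at which 3 of the 3 values shown sit.

The compounds shown leave open how these three truly compare, and whether any group on the amine nitrogen would give a readable number in this assay.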